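Halogen swap on the aryl ring of compound 1

The source may report more compounds than this note shows. Statements on the series, on what has been measured and on what is new or still open speak of the compounds shown alone.

Compound 1 `O=[N+]([O-])c1ccc(Nc2nccc(-c3ccc(F)cc3)n2)cc1` carries a nitro-substituted anilino group and a 4-fluorophenyl on the shared core. In a functional assay on MCF7 cells (Homo sapiens) for antiproliferative activity, read by MTT assay (on this read-out higher numbers stand for weaker inhibition and lower numbers for stronger inhibition), compound 1 gives 400 nM, the lowest of the three numbers in hand. Compound 3 `COc1cccc(Nc2nccc(-c3ccc(Cl)c(Cl)c3)n2)c1`, with a methoxy-substituted aniline and a dichlorophenyl, gives 21000 nM in this assay; compound 2 `CC(C)c1ccccc1Nc1nccc(-c2ccc(Br)cc2)n1`, with an isopropyl-substituted aniline and a bromophenyl, gives 111000 nM. Going by the values given here, both differ from compound 1 in more than one place, so their higher numbers cannot be assigned to the aniline or to the halogen, and no single-change step between measured compounds exists in this set.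

Compound 4 `O=[N+]([O-])c1ccc(Nc2nccc(-c3ccc(Br)cc3)n2)cc1` keeps the nitro-substituted anilino group of compound 1 and differs only as follows: bromo in place of fluoro on an aromatic carbon. The change sits on an aromatic carbon para to a large group and exchanges one halogen for another. Among the compounds with values here, no measured step of this kind is available to lean on. With nothing in hand pointing to a direction, the expected step in this assay is a 1.3-fold higher number from compound 1 to compound 4 (0.10 log units; within the scatter), which is within the usual scatter and no more than a slight lean toward a higher number. For compound 4 the estimate in this assay is 500 nM, with a range from 150 nM to 1700 nM.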

Compound 4, half-maximal inhibitory concentration: 681000 nM
Compound 4: middle estimate off by 1400-fold (3.13 log units), on the low side; the whole stated range lies below it.
By their numbers in this assay, from the lowest: compound 1; then compound 3; then compound 2; then compound 4.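

In this assay, going by these compounds alone, the exchange of 4-fluorophenyl for 4-bromophenyl with the nitro-substituted anilino group held constant gives a 1700-fold higher number from compound 1 to compound 4 (3.23 log units; beyond the scatter) and is the first single-change comparison. It shows that, with this aniline in place, the two halogens are not interchangeable on this aromatic carbon para to a large group: one halogen for another, with no change in ring, charge or hydrogen-bond donor and acceptor counts, is enough on its own to move the number far beyond the scatter. No measurement on these compounds accounts for the size of this step, and no cause can be assigned to it.

On these data alone, whether the step belongs to bromo alone or to its pairing with the nitro-substituted aniline stays open, since compound 2 and compound 3 each differ from compound 1 in more than one place. Also open, as far as these compounds go, is how a chloro, a nitrile or an amine on this same carbon would read with the nitro-substituted aniline, and whether any of them would stand nearer compound 1 or compound 4.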